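A few compounds are considered here, and "the series" means these few. Any claim that something is new, unique, unknown or untested is made for them only; others in the source may bear on it.

The measured compounds:
compound 1, `C=C(Cc1ccccc1)C(=O)Nc1ccccc1`, > 8.53 h
compound 2, `O=C(/C=C/CN1CCCC1)Nc1ccccc1`, 2.7 h

In an ADME assay for pharmacokinetics, read by LC-MS, in phosphate buffer, with a stated time of 120 min, at pH 7.4, tested at 1 uM, in the presence of a further agent that is not named here (on this read-out lower numbers stand for a shorter-lived compound and higher numbers for a longer-lived compound), compound 1 gives > 8.53 h, which is a limit of the assay rather than a number; this is the limit of > 8.53 h in this assay, at which 1 of the 2 values shown sits. Compound 2 gives 2.7 h in this assay. Compound 3, `C=C(C)C(=O)Nc1ccccc1`, is not yet measured. It differs from compound 1 by hydrogen in place of phenyl on a saturated chain carbon bound to a double-bonded chain carbon. Among the compounds with values here, with no step between measured compounds to lean on, the expected change in this assay is none beyond the scatter, so the estimated step is an at least 1.0-fold lower number from compound 1 to compound 3 (0.02 log units; that floor lies within the scatter). Compound 3 is therefore expected to give about 8 h in this assay, within a range from 3 h to 20 h.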

Compound 3, half-life: > 8.53 h
Compound 3: a limit, no number (the forecaster's own chance of this, stated with the estimate: 45%); middle value at least 1.0-fold (0.02 log units) from the limit.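

Within the data shown here, no step from compound 1 to compound 3 can be read in this assay, since both values are limits: the limit of > 8.53 h in this assay, at which 2 of the 3 values shown sit. The compounds shown leave open what the actual half-life of either compound is, and whether hydrogen in place of phenyl changes it at all.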